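This account rests on a few compounds, and the source may have more. Where it says the series, first, only, none or still open, it means among the compounds named here.

Measured in a functional assay on SW480 cells (Homo sapiens) for cytotoxicity, read by MTT assay, with a stated time of 48 h; a lower number here means a stronger inhibitor, a higher number a weaker inhibitor:
- compound 1 `CCOC(=O)C1(C(=O)Nc2ccccc2)CC1c1cc(OC)c(OC)c(OC)c1`: 49000 nM; > 100000 nM (2 entries)
- compound 2 `CCOC(=O)[C@]1(C(=O)Nc2ccccc2)C[C@H]1c1cc(OC)c(OC)c(OC)c1`: > 100000 nM

Compound 1 has one number and one limit of the assay among its entries. Compound 2 stands only at a limit of the assay, > 100000 nM, so it has no number. What separates the two is the fact that one of compounds 1 and 2 is drawn with a defined configuration and the other without, at the place where they differ.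

Next is compound 3 `COc1cc([C@@H]2C[C@]2(CO)C(=O)Nc2ccccc2)cc(OC)c1OC`, with hydroxymethyl in place of ethoxycarbonyl on a saturated ring carbon. Going by the values given here, no measured pair shows the size of this change, so the expectation in this assay rests on the weak readings alone. Compound 3 is expected to stay weak, and a reading at the limit again would be no surprise. The expected shift, an at least 1.4-fold lower number from compound 2 to compound 3 (0.15 log units; that floor lies within the scatter), is a small one towards a stronger reading. Compound 3 is estimated at 70000 nM, with an expected range from 20000 nM to 180000 nM.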

Compound 3, half-maximal inhibitory concentration: 33300 nM
Estimate against measurement, compound 3: 2.1-fold (0.32 log units) above, within the range that was stated.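

In this assay, the saturated ring carbon of the three-membered ring now has its first readable step: hydroxymethyl in place of ethoxycarbonyl gives an at least 3.0-fold lower number from compound 2 to compound 3 (0.47 log units; beyond the scatter). Compound 2 stands only at a limit of the assay, > 100000 nM, so this step gives a floor for the change and no upper end. Ethoxycarbonyl is therefore not required at this position for a numerical reading, although compound 3, at 33300 nM, remains weak in this assay.

The compounds shown do not separate the loss of ethoxycarbonyl from the arrival of the hydroxyl of hydroxymethyl, a question that a methyl, an aminomethyl or a carboxylic acid at the same carbon would bear on. From the compounds shown here alone, whether any group at this position brings a much stronger reading also remains open.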